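Compound 2 to compound 4: hydrogen in place of methoxy

A few compounds are considered here, and "the series" means these few. Any claim that something is new, unique, unknown or untested is made for them only; others in the source may bear on it.

For the measured compounds named here, in a functional assay on FaDu cells (Homo sapiens) for cytotoxicity, read by MTT assay, with a stated time of 72 h (on this read-out lower numbers stand for higher toxicity in this test and higher numbers for lower toxicity in this test), compound 2 (`COc1ccc(NC(=O)C(=O)c2cn(C(C)C)c3ccccc23)cn1`) gives 85 nM, the lowest of the three numbers so far. Compound 1 (`CCOc1ccc(NC(=O)C(=O)c2cn(C(C)C)c3ccccc23)cn1`) gives 175 nM, and compound 3 (`COc1ccc(NC(=O)C(=O)c2cn(C3CCCC3)c3ccccc23)cn1`) gives 370 nM. Compound 4 (`CC(C)n1cc(C(=O)C(=O)Nc2cccnc2)c2ccccc21`) is still unmeasured. It differs from compound 2 by hydrogen in place of methoxy on an aromatic carbon, so that 6-methoxypyridin-3-yl becomes pyridin-3-yl: hydrogen in place of methoxy on an aromatic carbon.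

Going by the values given here, two measured steps bear on this only indirectly. The step at the same aromatic carbon, a 2.1-fold lower number from compound 1 to compound 2 (0.31 log units; beyond the scatter), is modest, but it shortens the chain and keeps the oxygen. The step on the aromatic nitrogen, a 4.4-fold higher number from compound 2 to compound 3 (0.64 log units; beyond the scatter), is also modest and lies elsewhere in the molecule. Among the compounds with values here, no measured compound lacks the oxygen-linked chain, so the direction remains uncertain. With compound 2 already lowest at 85 nM, a modest rise in this assay seems more likely than a further fall. The expected change is a 2.2-fold higher number from compound 2 to compound 4 (0.35 log units; beyond the scatter), of similar size to the measured steps. Compound 4 is estimated at 190 nM, with an expected range of 50 nM to 700 nM.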

Compound 4, concentration lethal to 50% of the cells: > 10000 nM
Compound 4: only a limit was reported; the forecaster's own chance of this, stated with the estimate: 3%; middle value at least 52-fold (1.72 log units) from the limit.
By their numbers in this assay, from the lowest: compound 2; then compound 1; then compound 3. At a limit, above all of these: compound 4.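

The value of compound 4 in this assay is a limit of the assay, not a number: the limit of > 10000 nM in this assay, at which 1 of the 4 values shown sits. Hydrogen in place of methoxy gives an at least 110-fold higher number from compound 2 to compound 4 (2.07 log units; beyond the scatter), and hydrogen in place of ethoxy gives an at least 57-fold higher number from compound 1 to compound 4 (1.75 log units; beyond the scatter); both are far larger than a 2.1-fold lower number from compound 1 to compound 2 (0.31 log units; beyond the scatter), where the oxygen stays on the ring and only the chain shortens. Among the compounds shown, the read-out therefore tolerates a change in the length of the oxygen-linked chain at this aromatic carbon next to the ring nitrogen, but not loss of the whole group, and this change also outweighs a 4.4-fold higher number from compound 2 to compound 3 (0.64 log units; beyond the scatter) on the aromatic nitrogen.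

Going by these compounds, whether the oxygen or the carbon chain matters more remains open: a hydroxyl, an amine or a methyl group on this carbon would separate the two, and a longer chain such as propoxy would test how far the difference between compound 1 and compound 2 extends. Also open, on these data alone, is whether the same loss would appear with cyclopentyl on the aromatic nitrogen, as in compound 3.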